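Swapping a formyl chain end for acetoxymethyl

The source may hold more compounds than are shown below. What is called first, only, known or untested is meant among the compounds shown, and "the series" means these compounds.

Measured so far in a functional assay on SK-MEL-5 cells (Homo sapiens) for antiproliferative activity (a lower number here means a stronger inhibitor of growth, a higher number a weaker inhibitor of growth), for growth inhibition
- compound 1 `COC(=O)CCCCCCCCCCCCCC/C=C1\CC(CO)(COC(=O)C(C)(C)C)OC1=O` gives 7.8 ug/mL
- compound 2 `CCCCCOCCCCCCC/C=C1\CC(CO)(COC(=O)C(C)(C)C)OC1=O` gives 2.99 ug/mL
- compound 3 `CC(C)(C)C(=O)OCC1(CO)C/C(=C\CCCCCCCCCCCCCCC=O)C(=O)O1` gives > 10 ug/mL

For compound 3 the reading > 10 ug/mL is a limit and not a number.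

Compound 4 `CC(=O)OCCCCCCCCCCCCCCC/C=C1\CC(CO)(COC(=O)C(C)(C)C)OC1=O` carries acetoxymethyl in place of formyl on a saturated chain carbon, ten or more bonds along the chain from a double-bonded chain carbon. Among the measured compounds shown here, no measured step makes this exact change. The nearest is hydrogen in place of methoxy on a carbonyl carbon (an at least 1.2-fold higher number from compound 1 to compound 3 (0.10 log units; that floor lies within the scatter)), whose floor lies within the scatter. The other two chain changes are also not large (a 2.6-fold lower number from compound 1 to compound 2 (0.42 log units; beyond the scatter); an at least 3.3-fold higher number from compound 2 to compound 3 (0.52 log units; beyond the scatter)). Compound 4 is therefore expected to read near compound 1 (7.8 ug/mL). A modest move to a lower number is expected (an at least 1.5-fold lower number from compound 3 to compound 4 (0.18 log units; that floor lies within the scatter)). The estimate for compound 4 is 6.5 ug/mL (expected range 2.5 ug/mL to 14 ug/mL).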

Compound 4, concentration for 50% growth inhibition: 5.62 ug/mL
For compound 4 the middle estimate is 1.2-fold (0.06 log units) above the measured one; the measured number falls inside the stated range.
By their numbers in this assay, from the lowest: compounds 2, 4 and 1 (each within the scatter of the next, the first and the last beyond it). At a limit, above all of these: compound 3.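

In this assay, from the compounds shown here alone, acetoxymethyl in place of formyl at the chain end gives an at least 1.7-fold lower number from compound 3 to compound 4 (0.25 log units; that floor lies within the scatter) and so a step whose full size stays unknown. Acetoxymethyl in place of methoxycarbonyl gives a 1.4-fold lower number from compound 1 to compound 4 (0.14 log units; within the scatter) and 8-acetoxyoctyl in place of pentyloxy gives a 1.9-fold higher number from compound 2 to compound 4 (0.27 log units; within the scatter) so neither swap separates these chain ends here. Compound 3 stands at a limit and not at a number: the limit of > 10 ug/mL in this assay, at which 1 of the 4 values shown sits.

Going by these compounds, how far the formyl end really lies from the others stays open. So does how a chain ending in a free hydroxyl, an amine or a carboxylic acid would read.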